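Swapping the trifluoromethyl of compound 3 for methyl

A few compounds are considered here, and "the series" means these few. Any claim that something is new, unique, unknown or untested is made for them only; others in the source may bear on it.

Measured compounds in an assay on isolated protein for inhibition of protein kinase C zeta type (Homo sapiens), read by 33P incorporation, tested at 50 uM; a lower number here means a weaker effect, a higher number a stronger effect of the compound at the concentration tested:
compound 1 `O=C(O)CC(Cc1nc2cc(Cl)ccc2[nH]1)c1ccc(Cl)cc1` gives 0%
compound 2 `O=C(O)CC(Cc1nc2cc(Br)ccc2[nH]1)c1ccc(Cl)cc1` gives 25%
compound 3 `O=C(O)CC(Cc1nc2cc(C(F)(F)F)ccc2[nH]1)c1ccc(Cl)cc1` gives 35%

Compound 3 has the highest of the three numbers in this assay; compound 2 sits a number 10 percentage points higher from compound 2 to compound 3 (within the scatter), and compound 1 lies a number 35 percentage points higher from compound 1 to compound 3 (beyond the scatter). Compound 4 `Cc1ccc2[nH]c(CC(CC(=O)O)c3ccc(Cl)cc3)nc2c1` differs from compound 3 in one place: methyl in place of trifluoromethyl on an aromatic carbon. Within the data shown here, no measured step exchanges trifluoromethyl for methyl, so the two steps ending at compound 3 are the only guide: the chloro-to-trifluoromethyl step, a number 35 percentage points higher from compound 1 to compound 3 (beyond the scatter), and the bromo-to-trifluoromethyl step, a number 10 percentage points higher from compound 2 to compound 3 (within the scatter). Among the measured compounds shown here, since the substituent replacing trifluoromethyl in compound 4 was the one in compound 3 that coincided with the highest number, a drop is expected, of size a number 20 percentage points lower from compound 3 to compound 4 (beyond the scatter). Compound 4 is therefore estimated to give 15% in this assay, ranging from 0% to 35%.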

Compound 4, a percentage reported as inhibition, at one concentration (the size of the read-out at that concentration, not a potency): 0%
The estimate for compound 4 lay 15 percentage points above the measured number; low and high end bracket the measured number.
By their numbers in this assay, from the lowest: compounds 1 and 4 (each within the scatter of the next); then compounds 2 and 3 (each within the scatter of the next).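

In this assay methyl lines up with chloro at this aromatic carbon: the data show no change at the digits printed from compound 1 to compound 4 (within the scatter) yet also a number 25 percentage points lower from compound 2 to compound 4 (beyond the scatter) and a number 35 percentage points lower from compound 3 to compound 4 (beyond the scatter) in the same series. Of the four groups compared here, only bromo and trifluoromethyl lift the read-out over that of compound 1 and compound 4, so a single swap at this carbon can decide whether any inhibition appears at the concentration tested.

Going by these compounds, whether a methoxy group or an amine here would side with bromo and trifluoromethyl or with chloro and methyl stays open. Nothing at hand explains why the four groups divide this way.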